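A few compounds are considered here, and "the series" means these few. Any claim that something is new, unique, unknown or untested is made for them only; others in the source may bear on it.

Measured compounds in a functional assay on A549 cells (Homo sapiens) for antiproliferative activity, read by MTT assay, with a stated time of 48 h; a lower number here means a stronger inhibitor, a higher number a weaker inhibitor:
- Compound 1, `N#CC1=C(N)Oc2c(c3nc4ccccc4nc3c3ccccc23)C12C(=O)N(Cc1cnnn1-c1cccc(Cl)c1)c1ccccc12`, gives 32600 nM.
- Compound 2, `N#CC1=C(N)Oc2c(c3nc4ccccc4nc3c3ccccc23)C12C(=O)N(Cc1cnnn1-c1ccccc1Br)c1ccccc12`, reaches only a limit of the assay, > 50000 nM.
- Compound 3, `CCOc1ccc(-n2nncc2CN2C(=O)C3(C(C#N)=C(N)Oc4c3c3nc5ccccc5nc3c3ccccc43)c3ccccc32)cc1`, gives 25200 nM.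

Compound 3 and compound 1 sit within the scatter of each other, as the step of a 1.3-fold lower number from compound 1 to compound 3 (0.11 log units; within the scatter) shows. The value of compound 2 is a limit and not a number, so it allows no ranking against compound 3.

Compound 4, `Cc1cc(C)cc(-n2nncc2CN2C(=O)C3(C(C#N)=C(N)Oc4c3c3nc5ccccc5nc3c3ccccc43)c3ccccc32)c1`, differs from compound 3 in one place: 3,5-dimethylphenyl in place of 4-ethoxyphenyl on an aromatic nitrogen. All three measured steps concern the same aryl group on that aromatic nitrogen. The step of a 1.3-fold lower number from compound 1 to compound 3 (0.11 log units; within the scatter) is within the scatter, and the steps of an at least 1.5-fold higher number from compound 1 to compound 2 (0.18 log units; that floor lies within the scatter) and an at least 1.9-fold lower number from compound 2 to compound 3 (0.29 log units; that floor lies within the scatter) have floors that also lie within the scatter, with the limit of > 50000 nM in this assay, at which 1 of the 3 values shown sits, setting those floors. Exchanges of this aryl group therefore have not produced a step beyond the scatter among the shared core's measured compounds, and the 3,5-dimethylphenyl is expected to behave alike.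

The expected step is a 1.1-fold higher number from compound 3 to compound 4 (0.05 log units; within the scatter), no change beyond the scatter. For compound 4 the estimate in this assay is 28000 nM, with a range from 12000 nM to 60000 nM.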

Compound 4, half-maximal inhibitory concentration: > 50000 nM
Compound 4 gave a limit, no number; the forecaster's own chance of this, stated with the estimate: 30%; middle value at least 1.7-fold (0.25 log units) away from the limit.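

In this assay, compound 4 reaches only a limit of the assay, which places the 3,5-dimethylphenyl group alongside the 2-bromophenyl group of compound 2, so the position now gives a limit as often as a number: the limit of > 50000 nM in this assay, at which 2 of the 4 values shown sit.

Two new steps can be read, an at least 1.9-fold higher number from compound 3 to compound 4 (0.29 log units; that floor lies within the scatter) and an at least 1.5-fold higher number from compound 1 to compound 4 (0.18 log units; that floor lies within the scatter); both are floors, so neither shows a change beyond the scatter, and neither sets an upper bound on the true size of the step. The step between the two limits cannot be read, which leaves the 2-bromophenyl and 3,5-dimethylphenyl groups unranked, and numbers now stand only for the 3-chlorophenyl group of compound 1 and the 4-ethoxyphenyl group of compound 3.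

The compounds shown leave open whether any exchange of this aryl group can produce a step beyond the scatter in this assay. They also leave open how a phenyl group bearing an amine or a carboxylic acid, or a longer chain in place of the ethoxy group, would read at this position.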